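The source may report more compounds than this note shows. Statements on the series, on what has been measured and on what is new or still open speak of the compounds shown alone.

Measured compounds in a functional assay for agonist activity at growth hormone secretagogue receptor type 1 (Homo sapiens), read by FLIPR; on this read-out lower numbers stand for an effect already at smaller amounts and higher numbers for an effect only at larger amounts of compound:
compound 1 `COc1cc2c(cc1N1CCN[C@@H](C)C1)N(S(=O)(=O)c1ccc(-c3ccccn3)s1)CC2` — 3.16 nM
compound 2 `COc1cc2c(cc1N1CCN[C@H](C)C1)N(S(=O)(=O)c1ccc(-c3ccccn3)s1)CC2` — 3.98 nM
compound 3 `COc1cc2c(cc1N1C[C@@H](C)NC(C)(C)C1)N(S(=O)(=O)c1ccc(-c3ccccn3)s1)CC2` — 10 nM

Compound 3 stands at the highest number of the three, with compound 2 nearest and compound 1 furthest; both gaps are beyond the scatter. Compounds 1 and 2 sit within the scatter of each other, the step of a 1.3-fold higher number from compound 1 to compound 2 (0.10 log units; within the scatter) resting on (the fact that compounds 1 and 2 differ only in the configuration as drawn).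

Compound 4 `COc1cc2c(cc1N1CCNC(C)(C)C1)N(S(=O)(=O)c1ccc(-c3ccccn3)s1)CC2` has not yet been measured. It differs from compound 3 by hydrogen in place of methyl on a saturated ring carbon; what remains is the ring bearing two methyl groups on one carbon.

Among the compounds with values here, the steps that bear on this change are a 3.2-fold higher number from compound 1 to compound 3 (0.50 log units; beyond the scatter) and a 2.5-fold higher number from compound 2 to compound 3 (0.40 log units; beyond the scatter), each modest and beyond the scatter, where the larger ring group entered. Compound 4 removes one of the methyl groups added in those steps but keeps the pair of methyls, so it is expected to fall between compound 3 and compounds 1 and 2, a step of a 1.7-fold lower number from compound 3 to compound 4 (0.22 log units; within the scatter) toward a lower number, possibly within the scatter. Compound 4 is estimated at 6 nM, with a range from 3 nM to 13 nM.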

Compound 4, half-maximal effective concentration: 15.9 nM
Compound 4: middle estimate off by 2.7-fold (0.42 log units), on the low side; the whole stated range lies below it.
By their numbers in this assay, from the lowest: compounds 1 and 2 (each within the scatter of the next); then compounds 3 and 4 (each within the scatter of the next).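

Hydrogen in place of methyl next to the ring nitrogen gives a 1.6-fold higher number from compound 3 to compound 4 (0.20 log units; within the scatter), so this methyl makes no readable difference once the ring carbon bears two methyl groups. The gap to the compounds with a single methyl is thus already present with 3,3-dimethylpiperazin-1-yl in place of 3-methylpiperazin-1-yl, at a 4.0-fold higher number from compound 2 to compound 4 (0.60 log units; beyond the scatter) and a 5.0-fold higher number from compound 1 to compound 4 (0.70 log units; beyond the scatter). Both steps point the same way from either reference, and those two references lie within the scatter of each other: the fact that compounds 1 and 2 differ only in the configuration as drawn

Still open, from the compounds shown here alone, is how a piperazin-1-yl ring carrying no methyl would read against these values, which would set a baseline for the single methyl itself. Also open, going by these compounds, is whether an ethyl group on that ring carbon would extend the same trend.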